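The source may hold more compounds than are shown below. What is called first, only, known or untested is meant among the compounds shown, and "the series" means these compounds.

In an ADME assay on MDBK cells (Bos taurus) for cytotoxicity (on this read-out lower numbers stand for higher toxicity in this test and higher numbers for lower toxicity in this test), three compounds have been measured. Compound 1, `Cc1ccn(Cc2c(F)cccc2F)c2nc(-c3c(F)cccc3F)nc1-2`, reaches only the limit of the test, giving > 100000 nM. Compound 1 thus sits at the limit of > 100000 nM in this assay, at which 1 of the 3 values shown sits. Compound 2, `Brc1cccc(Cn2ccc3nc(-c4ccccc4)nc-3c2)c1`, gives 85000 nM, and compound 3, `FC(F)(F)c1cccc(Cn2ccc3nc(-c4ccccc4)nc-3c2)c1`, gives 98000 nM. Of the two numbers, compound 2 stands lowest, with compound 3 nearest: a 1.2-fold higher number from compound 2 to compound 3 (0.06 log units; within the scatter).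

The unmeasured compound 4, `CC(C)=CCn1ccc2nc(-c3ccccc3)nc-2c1`, differs from compound 2 at a single place: 2-methylprop-1-en-1-yl in place of 3-bromophenyl on a saturated chain carbon bound to an aromatic nitrogen. Among the compounds with values here, only one measured step touches the group on that carbon, namely a 1.2-fold higher number from compound 2 to compound 3 (0.06 log units; within the scatter), and it stays within the scatter. Within the data shown here, no measured step removes the aromatic ring altogether or places 2-methylprop-1-en-1-yl on that carbon, so the guide is thin. With both measured numbers lying close to the limit, compound 4 is expected to show little change beyond the scatter. The expected step is a 1.1-fold higher number from compound 2 to compound 4 (0.02 log units; within the scatter). Compound 4 is therefore estimated at 90000 nM, ranging from 40000 nM to 200000 nM.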

Compound 4, half-maximal cytotoxic concentration: > 100000 nM
Compound 4 gave a limit, no number; the forecaster's own chance of this, stated with the estimate: 40%; middle value at least 1.1-fold (0.04 log units) from the limit.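

In this assay, the step of an at least 1.1-fold higher number from compound 2 to compound 4 (0.07 log units; that floor lies within the scatter) shows that on the saturated chain carbon bound to an aromatic nitrogen, the 3-bromophenyl ring can be replaced by 2-methylprop-1-en-1-yl, with no ring in the entering group, and the read-out does not fall to a lower number. The earlier step at this place only exchanged one substituent on the aromatic ring, so it could not show this. Compound 4 gives a limit of the test and not a number, so only a floor for the step is known, and that floor lies within the scatter: the limit of > 100000 nM in this assay, at which 2 of the 4 values shown sit.

From the compounds shown here alone, whether an amine, a carboxylic acid or a longer chain on that carbon would give a lower number stays open. Going by these compounds, the true size of the change from compound 2 to compound 4 also stays open.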